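Replacing a phenoxy arm with a hydroxybenzyl arm

This account rests on a few compounds, and the source may have more. Where it says the series, first, only, none or still open, it means among the compounds named here.

Measured compounds:
Compound 1 `CC(=O)Oc1ccc(C(=O)Nc2cc3ccc(Oc4ccc(C(C)(C)C)cc4)c(C)c3oc2=O)cc1CC=C(C)C` — 72400 nM in a functional assay on SK-BR-3 cells (Homo sapiens) for antiproliferative activity; on this read-out lower numbers stand for stronger inhibition and higher numbers for weaker inhibition
Compound 2 `CC(C)=CCc1cc(C(=O)Nc2cc3ccc(Oc4ccc(C(C)(C)C)cc4)c(C)c3oc2=O)ccc1O` — in this assay compound 2 gives 68300 nM
Compound 3 `COCOc1ccc(Cc2ccc3cc(NC(=O)c4ccc(OC(C)=O)c(CC=C(C)C)c4)c(=O)oc3c2C)cc1` — in this assay compound 3 gives 13500 nM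

Compound 2 stands second highest of the three numbers; the step of a 1.1-fold lower number from compound 1 to compound 2 (0.03 log units; within the scatter) lies within the scatter, while compound 3 sits well lower. Compound 4 `CC(C)=CCc1cc(C(=O)Nc2cc3ccc(Cc4ccc(O)cc4)c(C)c3oc2=O)ccc1O` arises from compound 2 by 4-hydroxybenzyl in place of 4-(tert-butyl)phenoxy on an aromatic carbon. Going by the values given here, the one measured step that bears on this change is a 5.4-fold lower number from compound 1 to compound 3 (0.73 log units; beyond the scatter), where a benzyl group likewise replaced the 4-(tert-butyl)phenoxy group. A lower number of comparable size is therefore expected for compound 4, and the estimated step is a 4.9-fold lower number from compound 2 to compound 4 (0.69 log units; beyond the scatter). Compound 4 is estimated at 14000 nM, with a range from 4000 nM to 50000 nM.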

Compound 4, half-maximal inhibitory concentration: 21500 nM
For compound 4 the middle estimate is 1.5-fold (0.19 log units) below the measured one, within the range that was stated.
By their numbers in this assay, from the lowest: compounds 3 and 4 (each within the scatter of the next); then compounds 2 and 1 (each within the scatter of the next).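

In this assay, replacing 4-(tert-butyl)phenoxy with 4-hydroxybenzyl gives a 3.2-fold lower number from compound 2 to compound 4 (0.50 log units; beyond the scatter). The earlier benzyl step carried a methoxymethoxy group and an acetylated oxygen, so this shows that a lower number at this position also occurs with both hydroxyl groups free. No evidence explains this shift.

The change alters the linking atom and the ring substituent together, so their contributions cannot be separated. The compounds shown also leave open how a benzyl arm bearing an amine or a carboxylic acid would compare.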